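Aryl variation on the shared core: the 3,5-dimethylphenyl analogue

This account rests on a few compounds, and the source may have more. Where it says the series, first, only, none or still open, it means among the compounds named here.

Going by the values given here, compound 3 `Cc1nn(-c2nc(-c3ccc(Cl)c(Cl)c3)c(SC(C)C)s2)c(C(=O)O)c1-c1cccc(F)c1` gives the lowest number so far in a functional assay on BJAB cells (Homo sapiens) for antiproliferative activity, with a stated time of 4 days (a lower number here means that less compound is needed, a higher number that more compound is needed for the effect), 900 nM. Compound 1 `Cc1ccc(-c2c(C)nn(-c3nc(-c4ccc(Cl)c(Cl)c4)c(SC(C)C)s3)c2C(=O)O)cc1` is nearest with 3800 nM, and compound 2 `Cc1nn(-c2nc(-c3ccc(Cl)c(Cl)c3)c(SC(C)C)s2)c(C(=O)O)c1-c1cncnc1` is furthest with 22000 nM. The measured steps are a 4.2-fold lower number from compound 1 to compound 3 (0.63 log units; beyond the scatter), a 5.8-fold higher number from compound 1 to compound 2 (0.76 log units; beyond the scatter) and a 24-fold lower number from compound 2 to compound 3 (1.39 log units; beyond the scatter). Compound 4 `Cc1cc(C)cc(-c2c(C)nn(-c3nc(-c4ccc(Cl)c(Cl)c4)c(SC(C)C)s3)c2C(=O)O)c1` varies the same position: 3,5-dimethylphenyl in place of 3-fluorophenyl on an aromatic carbon. Of the measured steps, a 4.2-fold lower number from compound 1 to compound 3 (0.63 log units; beyond the scatter) bears most on it: 3,5-dimethylphenyl shares methyl substitution with 4-methylphenyl, whereas 3-fluorophenyl carries fluorine instead. Undoing that step in part, a modest rise is expected for compound 4, a 2.8-fold higher number from compound 3 to compound 4 (0.44 log units; beyond the scatter). Compound 4 is therefore estimated at 2500 nM, with a range from 700 nM to 9000 nM.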

Compound 4, half-maximal effective concentration: 2700 nM
For compound 4 the middle estimate is 1.1-fold (0.03 log units) below the measured one; the measured number falls inside the stated range.
By their numbers in this assay, from the lowest: compound 3; then compounds 4 and 1 (each within the scatter of the next); then compound 2.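

In this assay, a 1.4-fold lower number from compound 1 to compound 4 (0.15 log units; within the scatter) is a step that stays within the scatter, so 3,5-dimethylphenyl and 4-methylphenyl are not separated at this position. With a 3.0-fold higher number from compound 3 to compound 4 (0.48 log units; beyond the scatter) as a step beyond the scatter, 3-fluorophenyl keeps the lowest number against both methyl-bearing phenyl groups, and an 8.1-fold lower number from compound 2 to compound 4 (0.91 log units; beyond the scatter) places 3,5-dimethylphenyl well clear of pyrimidin-5-yl. No supporting data on the compounds bear on the cause of these differences.

Open, on these data alone, is how 3-methylphenyl, 4-fluorophenyl or 3-methoxyphenyl would compare at this position. Also open, as far as these compounds go, is whether the lower number of compound 3 follows the fluorine itself or its place on the ring.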